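The source may hold more compounds than are shown below. What is called first, only, known or untested is meant among the compounds shown, and "the series" means these compounds.

Measured in a functional assay on K562 cells (Homo sapiens) for inhibition, read by sulforhodamine B assay, with a stated time of 48 h; on this read-out higher numbers stand for weaker inhibition of growth and lower numbers for stronger inhibition of growth:
compound 1 `O=C(Nc1cccc(-n2cc(-c3ccncc3)c(-c3ccc(Cl)c(O)c3)n2)c1)Nc1cccc(C(F)(F)F)c1` gives a limit of the assay, > 32500 nM
compound 2 `COc1cc(-c2nn(-c3cccc(NC(=O)Nc4cc(C(F)(F)F)cc(C(F)(F)F)c4)c3)cc2-c2ccncc2)ccc1Cl` gives 3250 nM
compound 3 `COc1cc(-c2nn(-c3cccc(NC(=O)Nc4cccc(C(F)(F)F)c4)c3)cc2-c2ccncc2)ccc1Cl` gives a limit of the assay, > 50000 nM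

Compound 2 stands alone among these three as the only compound with a number in this assay. Compound 1 sits at a limit, (the limit of > 32500 nM in this assay, at which 1 of the 3 values shown sits). Compound 3 sits at another limit, (the limit of > 50000 nM in this assay, at which 1 of the 3 values shown sits).

Compound 4 `O=C(Nc1cccc(-n2cc(-c3ccncc3)c(-c3ccc(Cl)c(O)c3)n2)c1)Nc1cc(C(F)(F)F)cc(C(F)(F)F)c1` differs from compound 2 by hydrogen in place of methyl on an oxygen on an aromatic ring. The same change, taken the other way round, is the step that the two limits leave unreadable from compound 1 to compound 3, so it tells nothing about direction or size. The other measured step, an at least 15-fold higher number from compound 2 to compound 3 (1.18 log units; beyond the scatter), concerns a trifluoromethyl and does not touch the oxygen; it only shows that compound 2 carries a number where compound 3 does not. Within the data shown here, no measured step therefore shows which way removing the methyl moves the number, and the expectation in this assay is a step of no more than the scatter, a 1.5-fold higher number from compound 2 to compound 4 (0.19 log units; within the scatter). Compound 4 is thus estimated at 5000 nM, with a range from 1500 nM to 25000 nM.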

Compound 4, concentration for total growth inhibition: 3930 nM
Compound 4: the middle estimate sits 1.3-fold (0.10 log units) above what was measured, within the range that was stated.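

In this assay, among these compounds, the change from methoxy to hydroxy can now be read for the first time, and it gives a 1.2-fold higher number from compound 2 to compound 4 (0.08 log units; within the scatter), so the two groups cannot be told apart on this core. The trifluoromethyl change, until now readable only with the methoxy group present, can also be read with the hydroxy group, where it gives an at least 8.2-fold lower number from compound 1 to compound 4 (0.91 log units; beyond the scatter). The added trifluoromethyl thus goes with a lower number in both pairs, but the two sizes cannot be compared: the same change on two cores in this assay, an at least 15-fold higher number (1.18 log units; beyond the scatter) from compound 2 to compound 3 and an at least 8.2-fold higher number (0.91 log units; beyond the scatter) from compound 4 to compound 1; the limit leaves it open whether they differ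

Compound 1 and compound 3 both sit at limits of the assay, and the step between them cannot be read, so the methoxy to hydroxy change remains unresolved without the added trifluoromethyl. Also open, going by these compounds, is what an amine or an ethoxy group in place of the hydroxy would do to the number.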